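Cytotoxicity notes on a pyridazinone amide series

A few compounds are considered here, and "the series" means these few. Any claim that something is new, unique, unknown or untested is made for them only; others in the source may bear on it.

For the measured compounds named here, the three measured members share an aryl pyridazinone amide scaffold and were tested only in a functional assay on HepG2 cells (Homo sapiens) for cytotoxicity, read by MTT assay, with a stated time of 72 h; on this read-out lower numbers stand for stronger inhibition and higher numbers for weaker inhibition. Compound 1 `O=C(Nc1ccc(Oc2ccnc3[nH]ccc23)c(F)c1)c1nn(-c2ccc(Cl)cc2)ccc1=O` gives a limit of > 60000 nM in this assay and no numeric value. Compound 2 `Cn1ccc2c(Oc3ccc(NC(=O)c4nn(-c5ccc(Cl)c(F)c5)ccc4=O)cc3)ccnc21` likewise reaches only the limit of > 60000 nM. Compound 3 `Cc1cc(=O)n(-c2ccc(F)cc2)nc1C(=O)Nc1ccc(Oc2ncnc3[nH]ccc23)cc1` stands at the same place: in this assay compound 3 gives > 60000 nM, which is a limit of the assay and not a measured number. Where compound 3 stands on the numbers shown is therefore simply at the upper edge of what the assay can report, together with the two other compounds, as summarised by the limit of > 60000 nM in this assay, at which 3 of the 3 values shown sit.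

Compound 4 `Cc1cc(=O)n(-c2cccc(C(F)(F)F)c2)nc1C(=O)Nc1ccc(Oc2ncnc3[nH]ccc23)cc1` is the next member to be measured. It differs from compound 3 by 3-(trifluoromethyl)phenyl in place of 4-fluorophenyl on an aromatic nitrogen. Going by the values given here, no measured pair differs in one place, so no size of step is known for any change on the aromatic nitrogen of the shared core. Given that every value shown is a limit, the expectation for this assay is no step beyond the scatter, with compound 4 most likely again reported as a limit. The expected step from compound 3 to compound 4 is a step that the limit leaves unreadable from compound 3 to compound 4. For compound 4 the estimate in this assay is 70000 nM, within a range from 20000 nM to 200000 nM.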

Compound 4, half-maximal inhibitory concentration: 9470 nM
The estimate for compound 4 lay 7.4-fold (0.87 log units) above the measured number, and the stated range ends above it.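

In this assay, the aromatic nitrogen of the shared core emerges as a position where a change of aryl group can be read: 3-(trifluoromethyl)phenyl in place of 4-fluorophenyl gives an at least 6.3-fold lower number from compound 3 to compound 4 (0.80 log units; beyond the scatter). For the compounds shown here, this is the first step of any size, and it is only a minimum, so its full size cannot be read. The read-out is thus no longer flat across the series, but the single numeric reading still stands alone: the limit of > 60000 nM in this assay, at which 3 of the 4 values shown sit.

The compounds shown do not separate the contribution of the trifluoromethyl group from that of the loss of the fluorine, and they do not show whether a nitrile, a methoxy group, an amine or a carboxylic acid on the same phenyl ring would also give a numeric value. Going by these compounds, compound 1 and compound 2 differ from compound 4 in more than one place, so it also remains open whether 3-(trifluoromethyl)phenyl on the aromatic nitrogen would have a similar effect with their other parts of the structure.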